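Removing a Nitrile: Effect on Microsomal Clearance

This account rests on a few compounds, and the source may have more. Where it says the series, first, only, none or still open, it means among the compounds named here.

Of the compounds shown here, three sharing a common core have been measured in an ADME assay on microsomes from liver (Homo sapiens) for metabolic stability, read by LC-MS, using NADPH, tested at 1 uM; on this read-out lower numbers stand for slow clearance and higher numbers for fast clearance. Compound 1 `N#Cc1cnc(NC(=O)CCCOc2cccc(Cl)c2)s1` gives 115 mL.min-1.g-1 in this assay. Compound 2 `Cc1cnc(NC(=O)CCCOc2cccc(C#N)c2)s1` gives 172 mL.min-1.g-1, and compound 3 `Cc1cnc(NC(=O)NCCOc2ccc(Cl)c(C)c2)s1` gives 105 mL.min-1.g-1. Compound 2 carries the highest of the three numbers, but its gap to compound 1 and its gap to compound 3 both fall within the scatter of repeated measurements, so the three compounds cannot be told apart by this read-out; all of them are cleared quickly.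

Compound 4 `Cc1cnc(NC(=O)CCCOc2ccccc2)s1` has not yet been measured. It differs from compound 2 in one place: hydrogen in place of cyano on an aromatic carbon. For the measured compounds named here, no measured pair in this set shows the effect of such a change, so any expectation rests on the general picture alone. All three measured compounds show fast clearance, and compound 4 is expected to give a number of the same order, possibly somewhat higher, with an estimated step of a 1.3-fold higher number from compound 2 to compound 4 (0.11 log units; within the scatter). Compound 4 is therefore expected to give about 220 mL.min-1.g-1 in this assay, within a range from 100 mL.min-1.g-1 to 450 mL.min-1.g-1.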

Compound 4, intrinsic clearance in microsomes in the Homo sapiens assay: 175 mL.min-1.g-1
For compound 4 the middle estimate is 1.3-fold (0.10 log units) above the measured one; the range from low to high includes it.
By their numbers in the Homo sapiens assay, from the lowest: compounds 3, 1, 2 and 4 (each within the scatter of the next).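

For the compounds shown here, this is the first pair in the set that differs in one place only, and in the Homo sapiens assay the exchange of cyano for hydrogen on the aromatic carbon gives a 1.0-fold higher number from compound 2 to compound 4 (0.01 log units; within the scatter) and so does not separate the two compounds, which the earlier compounds, each differing in more than one place, could not show. In a physicochemical assay for solubility, read by nephelometry, in phosphate buffer, at pH 6.5 (a higher number here means a more soluble compound, a lower number a less soluble compound), compound 2 gives < 1100 nM as its result, which is a limit of the assay and not a number. In the physicochemical assay compound 4 gives < 1100 nM as its result, again a limit and not a number, and the step between the two compounds in that assay cannot be read, because both values sit at one limit: the limit of < 1100 nM in the physicochemical assay, at which 2 of the 2 values shown sit.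

The compounds shown leave open whether another group in this place, such as an amine, a carboxylic acid or a methoxy group, would give a clearance number that stands clear of the scatter. They also leave open how soluble compound 2 and compound 4 really are, and whether the same exchange of cyano for hydrogen would behave alike on a different chain.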